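Adding a methyl to the phenyl of compound 2

A few compounds are considered here, and "the series" means these few. Any claim that something is new, unique, unknown or untested is made for them only; others in the source may bear on it.

Of the compounds shown here, three sharing one core have been tested in an assay on isolated protein for agonist activity at Free fatty acid receptor 1 (Homo sapiens); on this read-out higher numbers stand for an effect only at larger amounts of compound and lower numbers for an effect already at smaller amounts. Compound 1 `CC#CC(CC(=O)O)c1ccc(OCc2ccc3nc(-c4ccc(CC)cc4)cn3c2)cc1` gives 496 nM. Compound 2 `CC#CC(CC(=O)O)c1ccc(OCc2ccn3cc(-c4ccccc4)nc3c2)cc1` gives 1260 nM, the highest of the three numbers, with compound 1 nearest to it. Compound 3 `CC#CC(CC(=O)O)c1ccc(OCc2ccc3nc(-c4ccc(OC)cc4)cn3c2)cc1` gives 47 nM, the lowest number and the furthest from compound 2; the gaps from compound 2 to both others lie beyond the scatter.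

The unmeasured compound 4 `CC#CC(CC(=O)O)c1ccc(OCc2ccn3cc(-c4ccc(C)cc4)nc3c2)cc1` differs from compound 2 in a single place: methyl in place of hydrogen on an aromatic carbon, para to a large group on the phenyl.

Going by the values given here, only one measured step is available, an 11-fold lower number from compound 1 to compound 3 (1.02 log units; beyond the scatter), and it was large. It exchanges one group for another at the same place on the phenyl, so it shows that this place can move the result strongly, but it does not involve a methyl or a hydrogen, and it runs on a differently arranged core. Among the compounds with values here, no step in these data tells what a methyl in place of hydrogen does here.

The expectation for compound 4 is therefore a modest move, a 1.6-fold lower number from compound 2 to compound 4 (0.20 log units; within the scatter), with a lower number slightly favoured but not assured. Compound 4 is estimated at 800 nM, within a range from 250 nM to 2500 nM.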

Compound 4, half-maximal effective concentration: 618 nM
Beside the measured number, compound 4's estimate is 1.3-fold (0.11 log units) above it; the range from low to high includes it.
By their numbers in this assay, from the lowest: compound 3; then compounds 1 and 4 (each within the scatter of the next); then compound 2.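

Read in this assay, the methyl on the phenyl gives the first direct measure of this change, with a 2.0-fold lower number from compound 2 to compound 4 (0.31 log units; beyond the scatter) as a modest step that lies just beyond the scatter. Going by these compounds alone, the only earlier step at this place, an 11-fold lower number from compound 1 to compound 3 (1.02 log units; beyond the scatter) on a differently arranged core, exchanged one group for another and never started from an unsubstituted phenyl, whereas this result shows that on the core of compound 2 the position para to a large group can take a methyl and the number still falls. Nothing measured here explains this step, so the result records what the change does and not how it does it.

Going by these compounds, it remains open whether the methoxy of compound 3 or the ethyl of compound 1 would give a lower number still on the core of compound 2, and whether the same methyl would give a step of similar size on the core of compound 1. On these data alone, the outcome is equally open for other groups at this place, such as trifluoromethyl, an amine or a longer chain.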